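A few compounds are considered here, and "the series" means these few. Any claim that something is new, unique, unknown or untested is made for them only; others in the source may bear on it.

Measured so far:
compound 1 `CC1=C(/C=C/C(=O)/C=C/c2cccc(F)c2)C(C)(C)CCC1O` with 5600 nM in a functional assay on CWR22R cells (Homo sapiens) for cytotoxicity, read by MTT assay, with a stated time of 72 h; on this read-out lower numbers stand for stronger inhibition and higher numbers for weaker inhibition
compound 2 `CC1=C(/C=C/C(=O)/C=C/c2cccc(C)c2)C(C)(C)CCC1O` with 4400 nM in this assay

Compound 2 holds the lowest of the two numbers, and compound 1 lies a 1.3-fold lower number from compound 1 to compound 2 (0.10 log units; within the scatter) away, a gap within the scatter. Compound 3 `CC1=C(/C=C/C(=O)/C=C/c2cccc(C#N)c2)C(C)(C)CCC1O` differs from compound 2 by cyano in place of methyl on an aromatic carbon. For the measured compounds named here, the one measured step, fluoro to methyl on the same aromatic carbon, gave only a 1.3-fold lower number from compound 1 to compound 2 (0.10 log units; within the scatter), so the numbers offer no sign that a change at this position moves the read-out beyond the scatter. Compound 3 is therefore expected to give about 5000 nM, between 2000 nM and 12000 nM, an estimated step of a 1.1-fold higher number from compound 2 to compound 3 (0.06 log units; within the scatter).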

Compound 3, half-maximal inhibitory concentration: 2200 nM
Compound 3: middle estimate off by 2.3-fold (0.36 log units), on the high side; low and high end bracket the measured number.
By their numbers in this assay, from the lowest: compounds 3, 2 and 1 (each within the scatter of the next, the first and the last beyond it).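

In this assay, for the compounds shown here, the change to cyano gives the first step at this position to pass beyond the scatter: a 2.5-fold lower number from compound 1 to compound 3 (0.41 log units; beyond the scatter). The step of a 2.0-fold lower number from compound 2 to compound 3 (0.30 log units; within the scatter) stays within the scatter, so the position shows a modest response only between the cyano and fluoro groups, with the methyl group not set apart from either. No available evidence explains this difference.

The compounds shown leave open how an amine, a carboxylic acid or a longer chain on this aromatic carbon would read out. They also leave open whether the step from fluoro to cyano would hold on a different core.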